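Hydroxycyclohexyl Replaces Cyclopropylmethyl on the Ring Nitrogen

The source may report more compounds than this note shows. Statements on the series, on what has been measured and on what is new or still open speak of the compounds shown alone.

Compound 1 `N#Cc1c(-c2ccc3c(ccn3CC3CC3)c2)ccn2c(CC(F)(F)F)cnc12` was tested in a functional assay on CHO cells for agonist activity at metabotropic glutamate receptor 2 (Homo sapiens) (a higher number here means a larger maximal response, a lower number a smaller maximal response), where compound 1 reaches 230%. Compound 2 `N#Cc1c(-c2ccc3c(c2)OCCN3)ccn2c(CC(F)(F)F)cnc12`, built on the same core, gives 232% in this assay. Among the measured compounds shown here, the two numbers lie within the usual scatter of each other, so compound 1 stands level with the only other measured compound. Compound 3 `N#Cc1c(-c2ccc3c(ccn3[C@H]3CC[C@H](O)CC3)c2)ccn2c(CC(F)(F)F)cnc12` differs from compound 1 in one place: 4-hydroxycyclohexyl in place of cyclopropylmethyl on an aromatic nitrogen. For the measured compounds named here, no measured pair shows what such a change does here. A step of about a number 10 percentage points lower from compound 1 to compound 3 (within the scatter) in this assay is expected, not clearly beyond the scatter. Compound 3 is therefore estimated to reach 220%, with a likely range from 170% to 260%.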

Compound 3, largest response reached (Emax), in percent of the reference or control that the assay uses: 237%
Beside the measured number, compound 3's estimate is 17 percentage points below it; the measured number falls inside the stated range.
By their numbers in this assay, from the lowest: compounds 1, 2 and 3 (each within the scatter of the next).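

In this assay the swap to 4-hydroxycyclohexyl from cyclopropylmethyl on the aromatic nitrogen brings a number 7 percentage points higher from compound 1 to compound 3 (within the scatter) and so no clear shift in maximal response. This position therefore accepts a larger group with a six-membered ring, a hydrogen-bond donor and a hydrogen-bond acceptor, with the response held. Nothing measured here explains this result. Still open, from the compounds shown here alone, is whether an amine or a carboxylic acid on the cyclohexyl ring, or a longer chain on the same nitrogen, would hold the response as well.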